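From 4-methylphenyl to phenoxymethyl: estimating a partition value

The compounds below may be only part of what the source reports. "The series", "measured", "known", "first", "only" and "open" are said of these compounds alone.

Measured so far in a physicochemical assay for lipophilicity, read by LC-MS, using the shake flask method, in phosphate buffer, measured as octanol-water partition, with a stated time of 2 h, at pH 7.4 (a lower number here means a more polar compound, a higher number a more lipophilic compound), for three compounds:
Compound 1 `COc1ccc(Cn2cc(CO[C@H]3O[C@H](CO)[C@@H](O)[C@H](O)[C@@H]3O)nn2)cc1` gives -0.4
Compound 2 `Cc1ccc(-c2cn(C[C@H]3O[C@H](CO)[C@@H](O)[C@H](O)[C@@H]3O)nn2)cc1` gives 0.23
Compound 3 `OC[C@H]1O[C@H](Cn2cc(-c3ccc(C(F)(F)F)cc3)nn2)[C@@H](O)[C@@H](O)[C@@H]1O` gives 1.07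

Compound 2 holds the second highest of these three numbers, with compound 1 lower and compound 3 higher, and both gaps lie beyond the usual scatter. Compound 4 `OC[C@H]1O[C@H](Cn2cc(COc3ccccc3)nn2)[C@@H](O)[C@@H](O)[C@@H]1O` has not yet been measured. Compared with compound 2, it carries phenoxymethyl in place of 4-methylphenyl on an aromatic carbon of a five-membered aromatic ring with 3 nitrogen phenoxymethyl in place of 4-methylphenyl on an aromatic carbon and the rest of the molecule is treated here as the shared core.

Among the measured compounds shown here, only one measured step exists, and it bears on this change loosely. Trifluoromethyl in place of methyl on an aromatic carbon gave a number 0.84 log units higher from compound 2 to compound 3 (beyond the scatter) and this shows that a single group exchange can move the number beyond the scatter. For the measured compounds named here, no measured step makes the exchange in question. Going by the values given here, compound 1, the only measured compound with an oxygen-holding chain on that ring, gives -0.4 and so points to a lower number. In this assay the expected change is therefore downward and modest, and the estimated move is a number 0.48 log units lower from compound 2 to compound 4 (beyond the scatter) in size. For compound 4 the estimate is -0.25 with an expected range from -0.7 to 0.15 for the measurement.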

Compound 4, distribution coefficient: -0.83
Estimate against measurement, compound 4: 0.58 log units above; measured number below the stated range.
By their numbers in this assay, from the lowest: compound 4; then compound 1; then compound 2; then compound 3.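

At this position, an aromatic carbon of the five-membered aromatic ring with 3 nitrogen, putting phenoxymethyl in place of 4-methylphenyl in this assay gives a number 1.06 log units lower from compound 2 to compound 4 (beyond the scatter) in a single exchange. The only earlier step, trifluoromethyl in place of methyl on an aromatic carbon, went upward, so this is the first single exchange here shown to move the number downward, even though a six-membered aromatic ring of carbon only is present on both sides of the change. No measurement shown here accounts for the size of this fall.

As far as these compounds go, the exchange alters several things at once: it removes the methyl, adds an oxygen that counts as a hydrogen-bond acceptor, and changes how the six-membered ring is attached, so the contribution of each remains open. Compounds carrying a plain phenyl or a benzyl group at this carbon, or a chain of carbon only ending in a phenyl ring, would help to pull these apart, and an amine or a carboxylic acid here would show how the number responds to a charged group.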